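This account rests on a few compounds, and the source may have more. Where it says the series, first, only, none or still open, it means among the compounds named here.

Compound 2 `Cc1ccccc1C(=O)NCc1ccc(CNS(=O)(=O)c2ccccc2)cc1` gives the lower of the two numbers recorded so far in an assay on MDA-MB-231 cells for binding affinity to C-X-C chemokine receptor type 4 (Homo sapiens), read by immunofluorescence and microscopy, with stated times of 10 min and 30 min; a higher number here means that more compound is needed for the effect, a lower number that less compound is needed: compound 2 gives 1 nM, whereas compound 1 `O=C(NCc1ccc(CNS(=O)(=O)c2ccccc2)cc1)c1cccnc1` gives 10 nM. Among the measured compounds shown here, the two differ in a single group, and that step, a 10-fold lower number from compound 1 to compound 2 (1.00 log units; beyond the scatter), is the only measured change available to lean on. Compound 3 `O=C(NCc1ccc(CNS(=O)(=O)c2ccccc2)cc1)c1ccncc1` carries a different change on the same carbonyl carbon: pyridin-4-yl in place of 2-methylphenyl on a carbonyl carbon. The group entering here is an aromatic ring with one nitrogen, much like the group that left when compound 1 became compound 2, so the step from compound 1 to compound 2 is the relevant comparison, and it was modest but beyond the scatter. Running that change in reverse, the number is expected to rise by a comparable amount, a 10-fold higher number from compound 2 to compound 3 (1.00 log units; beyond the scatter), so compound 3 is estimated at 10 nM, with a likely range of 3 nM to 30 nM.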

Compound 3, effective concentration (reported as EC, without a stated level of effect): 10 nM
Compound 3: middle estimate and measured number agree at the digits printed; the range from low to high includes it.
By their numbers in this assay, from the lowest: compound 2; then compounds 1 and 3 (each within the scatter of the next).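

Moving the ring nitrogen on this carbonyl carbon, with pyridin-4-yl in place of pyridin-3-yl, gives no change at the digits printed from compound 1 to compound 3 (within the scatter) in this assay, so the two pyridinyl rings cannot be told apart here. The step with pyridin-4-yl in place of 2-methylphenyl, a 10-fold higher number from compound 2 to compound 3 (1.00 log units; beyond the scatter), shows that the gap to 2-methylphenyl holds for a second pyridinyl ring and not only for pyridin-3-yl. Nothing available explains this gap.

On these data alone, the change swaps a ring nitrogen for a ring of carbon only and adds a methyl at the same time, so the share of each remains open. Plain phenyl, which has neither the ring nitrogen nor the methyl, and pyridin-2-yl would be the groups to separate them.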